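The source may hold more compounds than are shown below. What is called first, only, known or untested is meant among the compounds shown, and "the series" means these compounds.

In a functional assay on K562 cells (Homo sapiens) for antiproliferative activity, read by MTT assay, with a stated time of 24 h (on this read-out higher numbers stand for weaker inhibition and lower numbers for stronger inhibition), compound 1 `COC(=O)c1scc(-c2ccc(NC(=O)c3ccccn3)cc2)c1OC` gives 24200 nM and compound 2 `COC(=O)c1scc(-c2ccc(NC(=O)c3ccc(F)c(Cl)n3)cc2)c1OC` gives 8250 nM. The result for compound 3 `COC(=O)c1scc(-c2ccc(NC(=O)c3ccc(C#N)nc3)cc2)c1OC` is "not determined" (no result reported), so it offers no number to start from. Compound 4 `COC(=O)c1scc(-c2ccc(NC(=O)c3ccc(C(F)(F)F)cc3)cc2)c1OC` has 4-(trifluoromethyl)phenyl in place of 6-cyanopyridin-3-yl on a carbonyl carbon.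

With no value for compound 3, neither the size nor the direction of this step can be stated. Within the data shown here, the only measured step that offers any guide is a 2.9-fold lower number from compound 1 to compound 2 (0.47 log units; beyond the scatter), a modest change beyond the scatter, made by putting 6-chloro-5-fluoropyridin-2-yl in place of pyridin-2-yl on a carbonyl carbon. It is a single pair and involves different groups, so it gives only weak guidance. Like compound 2 at 8250 nM, compound 4 carries a substituted ring at this place, so a value nearer to that of compound 2 than to that of compound 1 is expected, with wide uncertainty. In this assay, the estimated value for compound 4 is 12000 nM, with an expected range from 4000 nM to 35000 nM.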

Compound 4, half-maximal inhibitory concentration: 9260 nM
The estimate for compound 4 lay 1.3-fold (0.11 log units) above the measured number; low and high end bracket the measured number.
By their numbers in this assay, from the lowest: compounds 2 and 4 (each within the scatter of the next); then compound 1.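

Among these compounds, with 4-(trifluoromethyl)phenyl on the carbonyl carbon, a ring of carbon only replaces the pyridine-type rings of the earlier compounds, and the result is a 2.6-fold lower number from compound 1 to compound 4 (0.42 log units; beyond the scatter) and is beyond the scatter. Against the other substituted ring the result is a 1.1-fold higher number from compound 2 to compound 4 (0.05 log units; within the scatter) and lies within the scatter, so compound 2 and compound 4 cannot be told apart, and a ring nitrogen is not needed to reach this level. Compound 3 has no number, so its step to compound 4 cannot be read, and nothing available explains the steps that can be read.

As far as these compounds go, the step from compound 1 to compound 4 swaps the ring and adds a substituent at once, so the share of each stays open. Also open, from the compounds shown here alone, is how plain phenyl, or a ring carrying an amine or a carboxylic acid, would behave at this place.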